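Methoxy Additions on a Boron-Bearing Chalcone Series

The compounds below may be only part of what the source reports. "The series", "measured", "known", "first", "only" and "open" are said of these compounds alone.

Measured so far:
compound 1 `COc1ccccc1C(=O)/C=C/c1ccc2c(c1)B(O)OC2`: 3100 nM
compound 2 `COc1cccc(C(=O)/C=C/c2ccc3c(c2)B(O)OC3)c1`: 2100 nM
compound 3 `COc1ccc(C(=O)/C=C/c2ccc3c(c2)B(O)OC3)c(OC)c1`: 11200 nM

All three were tested in a functional assay on MDA-MB-231 cells (Homo sapiens) for cytotoxicity, read by MTT assay, with a stated time of 48 h; on this read-out higher numbers stand for weaker inhibition and lower numbers for stronger inhibition. Compound 1 and compound 2 contain the same atoms joined differently; the difference between the two cores is not broken down here, and their values lie within the usual scatter of each other. Compound 3 is reached from compound 1 by one change, (methoxy in place of hydrogen on an aromatic carbon), and that step was a 3.6-fold higher number from compound 1 to compound 3 (0.56 log units; beyond the scatter).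

Compound 4 `COc1ccc(C(=O)/C=C/c2ccc3c(c2)B(O)OC3)cc1OC` has not yet been measured. It is reached from compound 2 by methoxy in place of hydrogen on an aromatic carbon. Going by the values given here, this is the same kind of change as the one from compound 1 to compound 3, but not the same: in compound 3 the new methoxy is meta to a methoxy group, whereas in compound 4 it is ortho to a methoxy group. Among the compounds with values here, a step of similar direction and size is expected for compound 4, namely a 2.4-fold higher number from compound 2 to compound 4 (0.38 log units; beyond the scatter), because the one measured example of this kind of change gave a 3.6-fold higher number from compound 1 to compound 3 (0.56 log units; beyond the scatter). On that basis compound 4 is estimated at 5000 nM in this assay, with a likely range from 2000 nM to 14000 nM.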

Compound 4, half-maximal inhibitory concentration: 13200 nM
Compound 4: middle estimate off by 2.6-fold (0.42 log units), on the low side; measured number inside the range.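

Putting a methoxy group in place of a hydrogen gave a 6.3-fold higher number from compound 2 to compound 4 (0.80 log units; beyond the scatter) in this assay, which means weaker inhibition. The same change also raised the number on the other core, and the two steps cannot be told apart in size: the same change on two cores in this assay, a 3.6-fold higher number (0.56 log units; beyond the scatter) from compound 1 to compound 3 and a 6.3-fold higher number (0.80 log units; beyond the scatter) from compound 2 to compound 4, 1.7-fold (0.24 log units) apart, within the scatter of two such steps. In these two pairs, then, the direction of the change carried over from one core to the other, but two pairs cannot show that it would hold on a further core, and they cannot show how much the position matters, since the new methoxy sits in a different place in each pair.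

The compounds shown have only methoxy groups on this ring, so it remains open whether a hydroxyl group, an amine or a carboxylic acid in the same place would also raise the number. As far as these compounds go, it is also open whether a longer chain in place of the methoxy would give a step of similar size.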